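From 4-fluorophenyl to (3-hydroxyoxetan-3-yl)methoxy on a shared core

The compounds below may be only part of what the source reports. "The series", "measured", "known", "first", "only" and "open" are said of these compounds alone.

In an ADME assay on the whole organism (Mus musculus, strain C57BL/6J) for pharmacokinetics, with a stated time of 24 h, at a dose of 2 mg/kg by the intravenous route (on this read-out lower numbers stand for slow clearance and higher numbers for fast clearance), compound 3 (`CCCCOc1nc(-c2ccc(F)cc2)c(-c2ccc(S(C)(=O)=O)cc2)cc1CO`) gives 32.2 mL/min/kg. Compound 1 (`CCCCOc1nc(OCC(C)(C)O)c(-c2ccc(S(C)(=O)=O)cc2)cc1C(C)(C)O`) gives 58.8 mL/min/kg and compound 2 (`CCCCOc1nc(OCC(C)(C)O)c(-c2ccc(S(C)(=O)=O)cc2)cc1COCCO`) gives 55.4 mL/min/kg, and both lie within the usual scatter of compound 3. Compound 4 (`CCCCOc1nc(OCC2(O)COC2)c(-c2ccc(S(C)(=O)=O)cc2)cc1CO`) differs from compound 3 by one change: (3-hydroxyoxetan-3-yl)methoxy in place of 4-fluorophenyl on an aromatic carbon. Among the compounds with values here, the only measured step, a 1.1-fold lower number from compound 1 to compound 2 (0.03 log units; within the scatter), lies within the scatter and concerns a different place on the core, so it offers little direct guidance. Compound 1 and compound 2 do carry 2-hydroxy-2-methylpropoxy where compound 4 gains its new group, so a modest rise is expected. The estimated change is a 1.4-fold higher number from compound 3 to compound 4 (0.15 log units; within the scatter), no step beyond the scatter. For compound 4 the estimated value is 45 mL/min/kg, with an expected range of 25 mL/min/kg to 80 mL/min/kg.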

Compound 4, clearance: 68.6 mL/min/kg
The estimate for compound 4 lay 1.5-fold (0.18 log units) below the measured number, within the range that was stated.
By their numbers in this assay, from the lowest: compounds 3, 2, 1 and 4 (each within the scatter of the next, the first and the last beyond it).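

In this assay, within the data shown here, putting (3-hydroxyoxetan-3-yl)methoxy in place of 4-fluorophenyl gives a 2.1-fold higher number from compound 3 to compound 4 (0.33 log units; beyond the scatter) as the first step here beyond the usual scatter. Among these compounds, it is also the first direct look at the aromatic carbon next to the ring nitrogen, and it shows that the group on this carbon can shift clearance, with the 4-fluorophenyl compound giving the lower number of this pair. Nothing shown gives a cause for this rise. Still open, on these data alone, is whether an amine, a plain methoxy or a carboxylic acid on this carbon would bring clearance back towards that of compound 3.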